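Aryl ester variation on the shared core

The source may report more compounds than this note shows. Statements on the series, on what has been measured and on what is new or still open speak of the compounds shown alone.

Compound 1 `CC1=CC[C@H](C(C)C)c2cc(C)c(OC(=O)c3ccc(C)cc3)cc21` in a functional assay on U-251 cells (Homo sapiens) for antiproliferative activity, read by sulforhodamine B assay, with a stated time of 48 h, tested at 50 uM (on this read-out lower numbers stand for less inhibition and higher numbers for more inhibition at the one concentration tested (going by the name of the read-out)), gives 67.7%, the highest of the two numbers in the set. Compound 2 `Cc1cc2c(C(C)C)ccc(C)c2cc1OC(=O)c1ccc(C(F)(F)F)cc1`, which carries a different core and a trifluoromethyl on the ester ring, gives 16.5% in this assay, a number beyond the scatter below compound 1. Compound 3 `COc1cccc(C(=O)Oc2cc3c(C)ccc(C(C)C)c3cc2C)c1` is reported in this assay as "not active" (no number reported) and carries no number. Compound 4 `CC1=CC[C@H](C(C)C)c2cc(C)c(OC(=O)c3ccccc3)cc21` is not yet measured; it differs from compound 1 by hydrogen in place of methyl on an aromatic carbon. Among the measured compounds shown here, no step between measured compounds isolates a change on the ester ring, so the size of this step is uncertain; the expectation is a small decrease, possibly within the scatter, in this assay, as a number 12.7 percentage points lower from compound 1 to compound 4 (beyond the scatter). Compound 4 is estimated at 55%, within 30% to 75%.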

Compound 4, a percentage reported as inhibition, at one concentration (the size of the read-out at that concentration, not a potency): 25.8%
Compound 4: the middle estimate sits 29.2 percentage points above what was measured; the whole stated range lies above it.
By their numbers in this assay, from the lowest: compounds 2 and 4 (each within the scatter of the next); then compound 1.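

In this assay, among the compounds shown here, the change from 4-methylphenyl to phenyl on the shared core gives a number 41.9 percentage points lower from compound 1 to compound 4 (beyond the scatter) and is the first step to isolate the ester ring. The read-out at the one concentration tested therefore responds to this single methyl, para to a large group, although this rests on one pair. Nothing at hand accounts for the size of this step.

Going by these compounds, whether an amine, a carboxylic acid or a longer chain at this place would match compound 1 stays open. On these data alone, whether the step carries over to the core of compound 2 also stays open.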